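The source may hold more compounds than are shown below. What is called first, only, known or untested is meant among the compounds shown, and "the series" means these compounds.

Measured compounds:
- compound 1, `Cc1nn([C@H](C)c2ccc(Cl)cc2Cl)c2nc(N3CC[C@H](N4CCC[C@H]4C(N)=O)[C@H](C)C3)cnc12`: "not determined" (no result reported) in an assay on CCRF-CEM cells for antagonist activity at C-C chemokine receptor type 4 (Homo sapiens), read by CellTiter-Glo, with stated times of 30 min and 60 min, in the presence of a further agent that is not named here; a higher number here means a weaker inhibitor, a lower number a stronger inhibitor
- compound 2, `Cc1nn([C@H](C)c2ccc(Cl)cc2Cl)c2nc(C3=CC[C@H](N4CCC[C@H]4CO)[C@H](C)C3)cnc12`: 179 nM
- compound 3, `Cc1nn([C@H](C)c2ccc(Cl)cc2Cl)c2nc(N3CC[C@H](N4CCC[C@H]4CCC#N)[C@H](C)C3)cnc12`: 865 nM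

Two numbers exist in this assay, and compound 3 stands at the higher of them, the weaker end; compound 2 gives the lower number, and the gap between the two lies beyond the usual scatter. Compound 1 carries no result in this assay, so nothing can be said of where it would stand. Among the measured compounds shown here, no pair of measured compounds differs in one place only, so no clean single step is available to lean on.

The unmeasured compound 4, `Cc1nn([C@H](C)c2ccc(Cl)cc2Cl)c2nc(N3CC[C@H](N4CCCCC4)[C@H](C)C3)cnc12`, differs from compound 3 by piperidin-1-yl in place of 2-(2-cyanoethyl)pyrrolidin-1-yl on a saturated ring carbon. The change removes the 2-(2-cyanoethyl)pyrrolidin-1-yl group with its triple bond and its defined stereocentre and puts a plain piperidin-1-yl ring in its place.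

With no single step shown, the size of this change in the assay can only be guessed. It is expected to land at or somewhat above the number of compound 3, most likely within the scatter or a little beyond it toward a weaker inhibitor, that is an expected step of a 1.7-fold higher number from compound 3 to compound 4 (0.24 log units; within the scatter). Compound 4 is thus estimated at 1500 nM, with a range from 300 nM to 8000 nM.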

Compound 4, half-maximal inhibitory concentration: 361 nM
For compound 4 the middle estimate is 4.2-fold (0.62 log units) above the measured one; measured number inside the range.
By their numbers in this assay, from the lowest: compounds 2 and 4 (each within the scatter of the next); then compound 3.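

In this assay, among the compounds shown here, piperidin-1-yl in place of 2-(2-cyanoethyl)pyrrolidin-1-yl on this saturated ring carbon, next to the ring atom that bears a methyl group, gives a 2.4-fold lower number from compound 3 to compound 4 (0.38 log units; beyond the scatter), the first single-place comparison. The triple bond and the defined stereocentre of the departing group are therefore not required for a number in this range, and the smaller group, with 6 heavy atoms against 9, gives the lower number. However, this one step changes ring size, the chain and the stereocentre together, so it cannot be divided among them, and nothing available explains the shift.

On these data alone, it remains open whether the gain follows from the six-membered ring or from the loss of the 2-cyanoethyl chain, a question that a plain pyrrolidin-1-yl group at this position would address directly. Also open, as far as these compounds go, is how this position would respond to a morpholin-4-yl ring or to a piperidin-1-yl ring carrying a carboxylic acid or a primary amine.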